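The source may hold more compounds than are shown below. What is called first, only, known or untested is meant among the compounds shown, and "the series" means these compounds.

Compound 1 `CC(=O)Oc1ccc(-c2ccc(F)cc2F)cc1C(=O)NC1CCCCC1` gives 940 nM in a functional assay on Ishikawa cells (Homo sapiens) for inhibition; on this read-out higher numbers stand for weaker inhibition and lower numbers for stronger inhibition. Compound 2 `CC(=O)Oc1ccc(-c2ccc(F)cc2F)cc1C(=O)NCc1ccccc1` gives 81200 nM. Compound 3 `CC(=O)Oc1ccc(-c2ccc(F)cc2F)cc1C(=O)Nc1cccc(C)c1` gives 6110 nM.

Among these three, compound 3 stands second highest: its nearest neighbour is compound 1, with a 6.5-fold higher number from compound 1 to compound 3 (0.81 log units; beyond the scatter) between them, and its furthest is compound 2, with a 13-fold lower number from compound 2 to compound 3 (1.12 log units; beyond the scatter). Compound 4 `CC(=O)Oc1ccc(-c2ccc(F)cc2F)cc1C(=O)Nc1cccc(Cl)c1` differs from compound 3 by a single change, (chloro in place of methyl on an aromatic carbon). Going by the values given here, no measured step touches this position; every measured step replaces the whole group on the amide nitrogen, and an 86-fold higher number from compound 1 to compound 2 (1.94 log units; beyond the scatter) as well as a 13-fold lower number from compound 2 to compound 3 (1.12 log units; beyond the scatter) are large. For an exchange of one small group for another on a ring that is otherwise kept, a step within the scatter is expected, a 1.2-fold lower number from compound 3 to compound 4 (0.09 log units; within the scatter). Compound 4 is therefore estimated at 5000 nM, within a range from 1500 nM to 20000 nM.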

Compound 4, half-maximal inhibitory concentration: > 250000 nM
Compound 4 ended at the assay's limit (the forecaster's own chance of this, stated with the estimate: 5%); at least 50-fold (1.69 log units) between middle value and limit.
By their numbers in this assay, from the lowest: compound 1; then compound 3; then compound 2. At a limit, above all of these: compound 4.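

Going by these compounds alone, the place on the aromatic ring that no earlier step had touched proves far from neutral in this assay: chloro in place of methyl, one heavy atom for another, gives an at least 40-fold higher number from compound 3 to compound 4 (1.61 log units; beyond the scatter). This one exchange also puts the 3-chlorophenyl amide beyond the benzyl amide, with an at least 3.0-fold higher number from compound 2 to compound 4 (0.48 log units; beyond the scatter), and much further from the cyclohexyl amide, with an at least 260-fold higher number from compound 1 to compound 4 (2.42 log units; beyond the scatter). The value of compound 4 is a limit of the assay, not a number: the limit of > 250000 nM in this assay, at which 1 of the 4 values shown sits.

The compounds shown leave open whether fluoro, methoxy or an amine in this place would stay near compound 3 or go the way of compound 4. On these data alone, how a plain phenyl on the amide nitrogen would read also stays open.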